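A few compounds are considered here, and "the series" means these few. Any claim that something is new, unique, unknown or untested is made for them only; others in the source may bear on it.

Working notes on the series, read in an ADME assay on cells (Peritoneal macrophage, Mus musculus, strain Balb/c) for cytotoxicity, read by resazurin assay, with a stated time of 72 h; a lower number here means that less compound is tolerated, a higher number that more compound is tolerated. Compound 1 (`N/C(=N\O)c1ccc(C2=C(S(=O)(=O)c3ccc(F)cc3)CC3(CCCCC3)O2)cc1`) gives 92900 nM, compound 2 (`CC1(Cc2cc(C(F)(F)F)cc(C(F)(F)F)c2)CC(S(=O)(=O)c2ccc(F)cc2)=C(c2ccc(/C(N)=N/O)cc2)O1`) gives 43100 nM, and compound 3 (`CC1(Cc2ccc([N+](=O)[O-])cc2)CC(S(=O)(=O)c2ccc(F)cc2)=C(c2ccc(/C(N)=N/O)cc2)O1`) gives 97400 nM. Compound 3 stands at the tolerated end of this small set: it is level with compound 1 within the scatter, while compound 2 has a lower number, with a gap beyond the scatter.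

Going by the values given here, no two measured compounds differ in one place only, so no measured step bears directly on the next change. Compound 4 (`CC1(Cc2ccc(CO)cc2)CC(S(=O)(=O)c2ccc(F)cc2)=C(c2ccc(/C(N)=N/O)cc2)O1`) comes from compound 3 by hydroxymethyl in place of nitro on an aromatic carbon. In words, this is hydroxymethyl in place of nitro on an aromatic carbon, para to a large group.

In this assay, no step beyond the scatter is expected for this change. The basis is thin: two of the three compounds sit level, compound 1 at 92900 nM and compound 3 at 97400 nM, and compound 2 at 43100 nM goes against that picture. The estimated change, a 1.1-fold lower number from compound 3 to compound 4 (0.06 log units; within the scatter), is expected to stay within the scatter. For compound 4 the estimated value is 85000 nM, with an expected range from 42000 nM to 170000 nM.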

Compound 4, half-maximal cytotoxic concentration: > 100000 nM
Compound 4 was reported as a limit (the forecaster's own chance of this, stated with the estimate: 20%); at least 1.1-fold (0.07 log units) between middle value and limit.
By their numbers in this assay, from the lowest: compound 2; then compounds 1 and 3 (each within the scatter of the next). At a limit, above all of these: compound 4.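

In this assay, compound 4 is reported as > 100000 nM, which is a limit of the assay and not a number. Going by these compounds alone, this gives the first measured step at this position, and for hydroxymethyl in place of nitro on an aromatic carbon, para to a large group, it reads an at least 1.0-fold higher number from compound 3 to compound 4 (0.01 log units; that floor lies within the scatter). The change therefore brings no lower number that the data can show, though only a floor is available for the step, so its true size cannot be read from this result: the limit of > 100000 nM in this assay, at which 1 of the 4 values shown sits.

Going by these compounds, what stays open is whether the tolerance seen here holds for other groups at the same place, for example an amine, a carboxylic acid or a longer chain such as hydroxyethyl in place of the hydroxymethyl. Also open, on these data alone, is how far the number for the 4-(hydroxymethyl)benzyl compound lies past the limit, which only a read-out extending to higher concentrations could settle.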